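Closing a Ring on the Hydroxylated Carbon

The compounds below may be only part of what the source reports. "The series", "measured", "known", "first", "only" and "open" are said of these compounds alone.

Of the compounds shown here, two with a shared core have been measured in an assay (Equus caballus) for inhibition of Thromboxane-A synthase (Homo sapiens), using microsomes; a lower number here means a stronger inhibitor, a higher number a weaker inhibitor. Compound 1 `CC(C)(CCC/C=C(\c1ccccc1)c1cccnc1)C(=O)O` gives 21 nM in this assay. Compound 2 `CC(C)(O)C(CCC/C=C(\c1ccccc1)c1cccnc1)C(=O)O` gives 42 nM in this assay. Among the compounds with values here, of the two numbers measured, compound 2 has the highest, with compound 1 nearest, and the only measured step, a 2.0-fold higher number from compound 1 to compound 2 (0.30 log units; within the scatter), lies within the scatter, so neither compound can be called the stronger inhibitor.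

Compound 3 `O=C(O)C(CCC/C=C(\c1ccccc1)c1cccnc1)C1(O)CCCC1` has not yet been measured. It differs from compound 2 in one place: 1-hydroxycyclopentyl in place of 1-hydroxy-1-methylethyl on a saturated chain carbon bound to a carbonyl carbon and a saturated chain carbon. The measured step of a 2.0-fold higher number from compound 1 to compound 2 (0.30 log units; within the scatter) concerns a different change, the arrival of a hydroxyl group rather than the joining of two methyl groups into a ring, so it gives only a loose guide: one change on the chain carbon bound to a carbonyl carbon left the number within the scatter. Within the data shown here, no measured step covers a ring at this place. The step of a 1.1-fold higher number from compound 2 to compound 3 (0.03 log units; within the scatter) is therefore expected to be small, with no direction beyond the scatter. Compound 3 is expected to give 45 nM, within a range from 15 nM to 140 nM.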

Compound 3, half-maximal inhibitory concentration: 65 nM
Compound 3: middle estimate off by 1.4-fold (0.16 log units), on the low side; measured number inside the range.
By their numbers in this assay, from the lowest: compounds 1, 2 and 3 (each within the scatter of the next, the first and the last beyond it).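

In this assay the exchange of 1-hydroxy-1-methylethyl for 1-hydroxycyclopentyl gives a 1.5-fold higher number from compound 2 to compound 3 (0.19 log units; within the scatter) and so stays within the scatter, which means compound 2 and compound 3 cannot be ranked. The earlier step concerned the arrival of a hydroxyl group, whereas this one shows that, with the hydroxyl group kept, a five-membered ring of carbon with 6 heavy atoms can take the place of an open group with 4 on the saturated chain carbon bound to a carbonyl carbon and a saturated chain carbon, with no change that can be told from the scatter. No further measurement bears on this result, so what lies behind it stays unexplained.

The compounds shown leave open how far this tolerance extends, since a single ring says little about a 1-hydroxycyclohexyl group, with its six-membered ring, at the same carbon. They also leave open what the hydroxyl group contributes once the ring is present, a question that a plain cyclopentyl group or a 1-aminocyclopentyl group at this carbon could address.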